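The source may report more compounds than this note shows. Statements on the series, on what has been measured and on what is new or still open speak of the compounds shown alone.

Three nucleoside analogues, each built from a sugar ring joined to a pyrimidine base and carrying a long chain that begins at a triple bond, have been tested in an ADME assay on Vero cells (Homo sapiens) for cytotoxicity against Vero (Chlorocebus sabaeus), read by MTT assay; a lower number here means that less compound is tolerated, a higher number that more compound is tolerated. Compound 1 is `CCCCCCCCCCCC#Cc1cn([C@H]2C[C@H](F)[C@@H](CO)O2)c(=O)[nH]c1=O`, compound 2 is `CCCCCCCCC#Cc1cn([C@H]2CC[C@@H](CO)O2)c(=O)[nH]c1=O`, and compound 3 is `CCCCCCCCCC#Cc1cn([C@H]2CC[C@@H](CO)O2)c(=O)[nH]c1=O`. In this assay compound 1 gives > 100 ug/mL, which is a limit of the assay rather than a number. Compound 2 gives > 100 ug/mL in this assay, again a limit. Compound 3 likewise reaches only a limit, > 100 ug/mL, in this assay. All three values therefore sit at the limit of > 100 ug/mL in this assay, at which 3 of the 3 values shown sit.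

Compound 3 and compound 2 differ by hydrogen in place of methyl on a saturated chain carbon, eight bonds along the chain from a triple-bonded carbon. With both values at the limit, the step that the two limits leave unreadable from compound 3 to compound 2 has no readable size.

The unmeasured compound 4 is `CCCCCCCCCCC#Cc1cn([C@H]2C[C@H](F)[C@@H](CO)O2)c(=O)[nH]c1=O`. It differs from compound 1 by hydrogen in place of methyl on a saturated chain carbon, ten or more bonds along the chain from a triple-bonded carbon. For the measured compounds named here, this is the same kind of change as the one between compound 3 and compound 2, though not the same: the methyl that leaves sits at a different distance along the chain from a triple-bonded carbon in the two cases, as the two descriptions show. How the core of compound 1 differs from the core of compound 3 is not broken down here.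

The expectation for compound 4 rests on compound 1, which gives > 100 ug/mL in this assay. The step from compound 1 to compound 4 is expected to be small, a step that the limit leaves unreadable from compound 1 to compound 4, since the shortening of the chain by one methyl is a small change. Compound 4 is therefore estimated to give 150 ug/mL in this assay, within a range from 90 ug/mL to 300 ug/mL, and most likely to be reported again only as a limit.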

Compound 4, half-maximal cytotoxic concentration: > 100 ug/mL
Compound 4 was reported as a limit; the forecaster's own chance of this, stated with the estimate: 85%; the middle value lies beyond the limit too.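

In this assay compound 4 gives > 100 ug/mL, which is a limit of the assay and not a number. Compound 1 is also reported only as a limit, so no step can be read between compound 1 and compound 4. The compounds shown leave open how much of each is tolerated and whether chain length changes that, because all their values stand at the same limit: the limit of > 100 ug/mL in this assay, at which 4 of the 4 values shown sit.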